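Tetrazole-bearing analogues: amino-linked tetrazole variant

The source may report more compounds than this note shows. Statements on the series, on what has been measured and on what is new or still open speak of the compounds shown alone.

Working notes on two measured compounds and one open one. Compound 1 `O=C(O)CSc1cccc(NC(=O)CN2N=C(C3CCCCC3)c3ccccc3N(CC(=O)C3CCCC3)C2=O)c1` and compound 2 `CC(C)(C)C(=O)CN1C(=O)N(CC(=O)Nc2cccc(-c3nn[nH]n3)c2)N=C(C2CCCCC2)c2ccccc21` share the same core and differ in the group on an aromatic carbon of the six-membered aromatic ring. In a functional assay on stomach for antagonist activity at Gastrin/cholecystokinin type B receptor (Rattus norvegicus) (on this read-out lower numbers stand for tighter binding and higher numbers for weaker binding), compound 1 gives 1.48 nM, while compound 2 gives 7.76 nM. Compound 2 thus stands at the highest of the two numbers, and its gap to compound 1 lies beyond the scatter. Compound 3 `CN(c1cccc(NC(=O)CN2N=C(C3CCCCC3)c3ccccc3N(CC(=O)C(C)(C)C)C2=O)c1)c1nn[nH]n1` is the next variant in this line. It differs from compound 2 by (2H-tetrazol-5-yl)(methyl)amino in place of 2H-tetrazol-5-yl on an aromatic carbon. Among the measured compounds shown here, no measured pair shows a change of this kind, so nothing here fixes its size. The expectation for compound 3 in this assay is a modest step from compound 2 toward a weaker number, of about a 1.9-fold higher number from compound 2 to compound 3 (0.29 log units; within the scatter). Compound 3 is accordingly estimated at 15 nM, with a range from 4 nM to 60 nM.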

Compound 3, dissociation constant: 24 nM
Estimate against measurement, compound 3: 1.6-fold (0.20 log units) below; the range from low to high includes it.
By their numbers in this assay, from the lowest: compound 1; then compound 2; then compound 3.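

Among the compounds shown here, compound 2 and compound 3 give the first one-place comparison at this position: on an aromatic carbon of the six-membered ring, (2H-tetrazol-5-yl)(methyl)amino in place of 2H-tetrazol-5-yl gives, in this assay, a 3.1-fold higher number from compound 2 to compound 3 (0.49 log units; beyond the scatter). The position thus accepts the larger group with the tetrazole ring kept, at a modest cost, and compound 3 still reads 24 nM. Nothing available explains the size of this step.

Open, going by these compounds, is whether the step belongs to the amino nitrogen or to its methyl group; a plain amino link carrying the same tetrazole would separate the two. Also open, on these data alone, is how a carboxylic acid group at this position behaves with the rest of compound 2 unchanged, as compound 1 differs from compound 2 in more than one place.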